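The source may hold more compounds than are shown below. What is called first, only, known or untested is meant among the compounds shown, and "the series" means these compounds.

Compound 1 `COc1ccccc1/C=N/Nc1nc2ccccc2nc1Cc1ccccc1` stands highest of the two numbers in an assay on isolated protein for inhibition of Amine oxidase [flavin-containing] A (Homo sapiens), read by spectrophotometry; a lower number here means a stronger inhibitor, a higher number a weaker inhibitor; compound 1 gives 83 nM. Compound 2 `Clc1ccccc1/C=N/Nc1nc2ccccc2nc1Cc1ccccc1` gives 5.8 nM in this assay. Within the data shown here, the only step measured, a 14-fold lower number from compound 1 to compound 2 (1.16 log units; beyond the scatter), swaps the group itself rather than its position. Among the measured compounds shown here, compound 3 `COc1ccc(/C=N/Nc2nc3ccccc3nc2Cc2ccccc2)cc1` carries 4-methoxyphenyl in place of 2-methoxyphenyl on a carbon with a double bond to nitrogen; no measured step bears on such a shift of the same group, so the direction is open and a step beyond the scatter in either sense is possible. The expected step is a 1.4-fold lower number from compound 1 to compound 3 (0.14 log units; within the scatter), estimated. Compound 3 is expected near 60 nM, within 15 nM to 250 nM.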

Compound 3, half-maximal inhibitory concentration: 63 nM
Beside the measured number, compound 3's estimate is 1.1-fold (0.02 log units) below it, within the range that was stated.
By their numbers in this assay, from the lowest: compound 2; then compounds 3 and 1 (each within the scatter of the next).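

In this assay, moving the methoxy group from 2-methoxyphenyl to 4-methoxyphenyl on this carbon gives a 1.3-fold lower number from compound 1 to compound 3 (0.12 log units; within the scatter) and so resolves no preference between the two placements. The methoxy group in this new placement still leaves a clear gap to the chloro compound, with an 11-fold higher number from compound 2 to compound 3 (1.04 log units; beyond the scatter) as the step. No evidence on hand bears on this result.

As far as these compounds go, whether 4-chlorophenyl would keep the low number of compound 2 stays open, so the choice of group and its placement remain unseparated. From the compounds shown here alone, how an amine or a carboxylic acid would read on this ring is also open.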